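From benzyl(methyl)amino to (1-phenylethyl)amino

This account rests on a few compounds, and the source may have more. Where it says the series, first, only, none or still open, it means among the compounds named here.

In a functional assay on MDA-MB-231 cells (Homo sapiens) for antiproliferative activity, read by MTT assay, with a stated time of 24 h (on this read-out lower numbers stand for stronger inhibition and higher numbers for weaker inhibition), compound 1 `CCCCNC(=O)CCCOc1ccc(C(=O)c2c(CCCC)oc3ccccc23)cc1` gives 38100 nM. Compound 2 `CCCCc1oc2ccccc2c1C(=O)c1ccc(OCCCC(=O)N(C)Cc2ccccc2)cc1` gives only a limit, > 50000 nM, and its standing is the limit of > 50000 nM in this assay, at which 1 of the 2 values shown sits. Compound 3 `CCCCc1oc2ccccc2c1C(=O)c1ccc(OCCCC(=O)N[C@@H](C)c2ccccc2)cc1` carries (1-phenylethyl)amino in place of benzyl(methyl)amino on a carbonyl carbon. Among the measured compounds shown here, the one measured step at this place is an at least 1.3-fold higher number from compound 1 to compound 2 (0.11 log units; that floor lies within the scatter). With compound 1 and compound 2 this close in this assay, no step beyond the scatter is expected, in either direction. The estimated step is an at least 1.1-fold lower number from compound 2 to compound 3 (0.07 log units; that floor lies within the scatter). Compound 3 is expected at 42000 nM, with an estimated range from 20000 nM to 80000 nM.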

Compound 3, half-maximal inhibitory concentration: > 50000 nM
Compound 3: only a limit was reported; the forecaster's own chance of this, stated with the estimate: 50%; middle value at least 1.1-fold (0.07 log units) away from the limit.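

With the amide hydrogen present again and the same atoms as benzyl(methyl)amino, compound 3 still gives only a limit in this assay, > 50000 nM. Against butylamino, 1-phenylethyl in place of butyl on an amide-type nitrogen gives an at least 1.3-fold higher number from compound 1 to compound 3 (0.11 log units; that floor lies within the scatter). The step between compound 2 and compound 3 cannot be read because both compounds rest on the same limit: the limit of > 50000 nM in this assay, at which 2 of the 3 values shown sit.

Left open is whether morpholine or a carboxylic acid in place of these amino groups on the carbonyl carbon would move the read-out clearly away from compound 1 at 38100 nM.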